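Hydroxy to hydrogen: a step in the series

This account rests on a few compounds, and the source may have more. Where it says the series, first, only, none or still open, it means among the compounds named here.

In a physicochemical assay for lipophilicity, measured as octanol-water partition (a lower number here means a more polar compound, a higher number a more lipophilic compound), compound 1 (`O=C(COc1cccc2ccccc12)N/N=C/c1ccc([N+](=O)[O-])cc1`) gives 3.97. Compound 2 (`O=C(COc1cccc2ccccc12)N/N=C/c1ccccc1O`) gives 3.73, within the scatter of compound 1, so the two cannot be ranked. Compound 3 (`O=C(COc1cccc2ccccc12)N/N=C/c1ccccc1`) has hydrogen in place of hydroxy on an aromatic carbon, so 2-hydroxyphenyl becomes phenyl. Within the data shown here, no measured single-place step in this assay is available to set the size of this change. A small rise, close to the scatter, is expected, an estimated a number 0.17 log units higher from compound 2 to compound 3 (within the scatter). Compound 3 is expected at 3.9, with an estimated range of 3.55 to 4.25.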

Compound 3, partition coefficient: 4.02
Compound 3: the middle estimate sits 0.12 log units below what was measured; the measured number falls inside the stated range.
By their numbers in this assay, from the lowest: compounds 2, 1 and 3 (each within the scatter of the next).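

In this assay hydrogen in place of hydroxy on an aromatic carbon gives a number 0.29 log units higher from compound 2 to compound 3 (within the scatter) and hydrogen in place of nitro on an aromatic carbon gives a number 0.05 log units higher from compound 1 to compound 3 (within the scatter) as the second single-place step. Among these compounds, neither hydroxy nor nitro therefore separates from hydrogen on this ring, and these steps set a first size for such changes. Nothing measured here bears on the reason for these steps. From the compounds shown here alone, whether an amine or a carboxylic acid on this ring would step beyond the scatter remains open, as does whether the hydroxy step holds on another core.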